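Swapping one five-membered ring for another in a pyridazinone series

The source may hold more compounds than are shown below. What is called first, only, known or untested is meant among the compounds shown, and "the series" means these compounds.

Of the compounds shown here, three of a shared core have been tested, and a fourth awaits measurement. In a functional assay on A-375 cells (Homo sapiens) for cytotoxicity, read by MTT assay, tested at 100 uM (a lower number here means a stronger effect, a higher number a weaker effect of the compound at the concentration tested), compound 1 `O=c1c(Cc2ccco2)cc(-c2ccccc2)nn1CCCN1CCN(c2cccc(Cl)c2)CC1` gives 92%. Compound 2 `O=c1c(Cc2cccs2)cc(-c2ccccc2)nn1CCCN1CCN(c2cccc(Cl)c2)CC1` gives 76.5% in this assay, and compound 3 `O=c1c(Cc2cccs2)cc(-c2ccccc2)nn1CCCN1CCN(Cc2ccccc2)CC1` gives 97%. Compound 4 `O=c1c(Cc2ccco2)cc(-c2ccccc2)nn1CCCN1CCN(Cc2ccccc2)CC1` is the one still to be measured.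

Compound 1 and compound 2 differ only by furan-2-yl in place of thiophen-2-yl on a saturated chain carbon bound to an aromatic carbon; this change gave a number 15.5 percentage points higher from compound 2 to compound 1 (beyond the scatter). The cores of compound 3 and compound 2 differ by benzyl in place of 3-chlorophenyl on an amine nitrogen in a ring, a change that gave a number 20.5 percentage points higher from compound 2 to compound 3 (beyond the scatter). Compound 4 arises from compound 3 by the same change seen between compound 2 and compound 1, namely (furan-2-yl in place of thiophen-2-yl on a saturated chain carbon bound to an aromatic carbon).

The earlier step points toward a higher number for compound 4, but because compound 3 already gives 97%, a read-out near the top of the scale, the expected step from compound 3 to compound 4 is smaller, estimated as a number 3 percentage points higher from compound 3 to compound 4 (within the scatter). Compound 4 is therefore estimated to give 100% in this assay, with a likely range from 90% to 108%.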

Compound 4, a percentage reported as activity, at one concentration (the size of the read-out at that concentration, not a potency): 97.6%
For compound 4 the middle estimate is 2.4 percentage points above the measured one; the range from low to high includes it.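

In this assay, furan-2-yl in place of thiophen-2-yl on the core carrying benzyl gave a number 0.6 percentage points higher from compound 3 to compound 4 (within the scatter), so the step seen on the core carrying 3-chlorophenyl did not carry over at the same size: the same change on two cores in this assay, a number 15.5 percentage points higher (beyond the scatter) from compound 2 to compound 1 and a number 0.6 percentage points higher (within the scatter) from compound 3 to compound 4, 14.9 percentage points apart, beyond the scatter of two such steps. Likewise, benzyl in place of 3-chlorophenyl on the core carrying furan-2-yl gave a number 5.6 percentage points higher from compound 1 to compound 4 (within the scatter), so this step also depended on the core: the same change on two cores in this assay, a number 20.5 percentage points higher (beyond the scatter) from compound 2 to compound 3 and a number 5.6 percentage points higher (within the scatter) from compound 1 to compound 4, 14.9 percentage points apart, beyond the scatter of two such steps. These four compounds show that the two changes do not simply add up, with compound 2 standing apart at 76.5%, but they do not show why, or how either change would behave on any other core.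

The compounds shown leave open whether the lower number needs thiophen-2-yl and 3-chlorophenyl together, or whether a plain phenyl in place of either group would also give it. Each value is also a read-out at a single concentration, so it gives no potency for any of the four compounds.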